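The source may hold more compounds than are shown below. What is called first, only, known or untested is meant among the compounds shown, and "the series" means these compounds.

Measured in an ADME assay on Vero cells (Chlorocebus sabaeus) for cytotoxicity, read by CellTiter-Glo, with a stated time of 72 h; on this read-out lower numbers stand for higher toxicity in this test and higher numbers for lower toxicity in this test:
Compound 1 `[O-][n+]1nc(NC2CCC2)[n+]([O-])c2ccccc21`: 8.9 ug/mL
Compound 2 `CCNc1n[n+]([O-])c2cccc(C)c2[n+]1[O-]`: 22 ug/mL

Only these two compounds have been measured in this assay. Compound 2 holds the higher number at 22 ug/mL, while compound 1 stands lower at 8.9 ug/mL, a gap beyond the usual scatter. For the measured compounds named here, the two differ in more than one place, so no single-change step between measured compounds is available as a guide.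

Compound 3 `Cc1cccc2c1[n+]([O-])c(NC1CCC1)n[n+]2[O-]` is reached from compound 2 by one change, cyclobutyl in place of ethyl on a nitrogen on an aromatic ring, or ethylamino to cyclobutylamino. The expectation for this change rests on compound 1, which also carries cyclobutylamino and gives 8.9 ug/mL. A move to a lower number, and so to higher toxicity in this test, is therefore expected, of a size that may only just clear the scatter. The expected step is a 2.2-fold lower number from compound 2 to compound 3 (0.34 log units; beyond the scatter). For compound 3 the estimated value is 10 ug/mL, with an expected range of 4 ug/mL to 24 ug/mL.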

Compound 3, half-maximal cytotoxic concentration: 22 ug/mL
The estimate for compound 3 lay 2.2-fold (0.34 log units) below the measured number, and the stated range covers the measured number.
By their numbers in this assay, from the lowest: compound 1; then compounds 2 and 3 (each within the scatter of the next).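

Cyclobutyl in place of ethyl on a nitrogen on an aromatic ring gives, in this assay, no change at the digits printed from compound 2 to compound 3 (within the scatter) and so, with the methyl on the core, this change does not separate the two compounds. Methyl in place of hydrogen on an aromatic carbon, with cyclobutylamino held the same, gives a 2.5-fold higher number from compound 1 to compound 3 (0.39 log units; beyond the scatter) in a modest step, so among these three compounds the one single change that clears the scatter is the methyl, while the change on the nitrogen does not. Nothing in the data shown explains either result.

On these data alone, it remains open whether the nitrogen tolerates groups further from ethyl and cyclobutyl in the same way, such as a longer chain like hexyl or a ring carrying a hydroxyl group, and whether ethyl and cyclobutyl would also read alike on the core without the methyl. As far as these compounds go, it is equally open whether the step seen for methyl is particular to that group or would also appear with chlorine or methoxy on the same carbon.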